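The source may hold more compounds than are shown below. What is called first, only, known or untested is meant among the compounds shown, and "the series" means these compounds.

In an assay on isolated protein for activation of Nicotinamide phosphoribosyltransferase (Homo sapiens) (a higher number here means that more compound is needed for the effect, a lower number that less compound is needed), compound 1 `CN(Cc1ccccc1)S(=O)(=O)c1ccc(NC(=O)NCc2ccncc2)cc1` gives 23 nM, the lowest of the two numbers recorded here. Compound 2 `O=C(NCc1ccncc1)Nc1ccc(S(=O)(=O)N2CC3CCC(C2)O3)cc1` gives 279 nM in this assay, and the step of a 12-fold higher number from compound 1 to compound 2 (1.08 log units; beyond the scatter) is large. Compound 3 `CCOC(=O)c1ccc(N(C)C(=O)NCc2ccncc2)cc1` reaches only a limit of this assay, > 100000 nM, which the limit of > 100000 nM in this assay, at which 1 of the 3 values shown sits, records.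

Compound 4 `CNS(=O)(=O)c1ccc(NC(=O)NCc2ccncc2)cc1` differs from compound 1 by hydrogen in place of benzyl on a sulfonamide nitrogen. For the measured compounds named here, no measured step covers exactly this change; the only measured step at the sulfonyl sulfur, from compound 1 to compound 2, swapped the whole benzyl(methyl)amino group and raised the number. A loss of the benzyl group alone is therefore expected to raise the number as well, as an 8.7-fold higher number from compound 1 to compound 4 (0.94 log units; beyond the scatter). For compound 4 an estimate of 200 nM is expected, within 50 nM to 800 nM.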

Compound 4, half-maximal effective concentration: 3230 nM
For compound 4 the middle estimate is 16-fold (1.21 log units) below the measured one, outside the stated range (above it).
By their numbers in this assay, from the lowest: compound 1; then compound 2; then compound 4. At a limit, above all of these: compound 3.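

Hydrogen in place of benzyl on the sulfonamide nitrogen gives a 140-fold higher number from compound 1 to compound 4 (2.15 log units; beyond the scatter), so at this position the benzyl group counts for far more than the earlier step suggested. The group of compound 2 has no aromatic ring yet still outperforms methylamino, with a 12-fold higher number from compound 2 to compound 4 (1.06 log units; beyond the scatter), so a ring without aromatic character also retains much of the effect. Nothing measured here explains this loss.

Open, from the compounds shown here alone, is whether the benzyl group's aromatic ring matters, or only its bulk, which a cyclohexylmethyl group on that nitrogen would help separate. A longer chain such as phenethyl, or a benzylamino group without the methyl, would test the rest of this group.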